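Dropping one hydroxy group from compound 1

The source may hold more compounds than are shown below. What is called first, only, known or untested is meant among the compounds shown, and "the series" means these compounds.

Measured so far:
compound 1 `O=C1c2ccc(O)c(O)c2O[C@@H](c2cccc(O)c2O)[C@@H]1O`: > 100000 nM
compound 2 `O=C1c2c(O)cccc2O[C@H](c2cccc(O)c2O)[C@H]1O`: 77700 nM

Both compounds were tested in a functional assay on RAW264.7 cells (Rattus norvegicus) for inhibition, with RAW264.7 (Mus musculus) as the target, read by Griess assay, with stated times of 2 h and 16 h; on this read-out higher numbers stand for weaker inhibition and lower numbers for stronger inhibition. For compound 1 the result is only a limit of the assay and not a number, since compound 1 sits at the limit of > 100000 nM in this assay, at which 1 of the 2 values shown sits. Compound 2 gives 77700 nM in this assay, so both compounds show only weak inhibition.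

Compound 3 `O=C1c2ccc(O)cc2O[C@@H](c2cccc(O)c2O)[C@@H]1O` is the next compound. It differs from compound 1 in a single spot: hydrogen in place of hydroxy on an aromatic carbon. Going by the values given here, no pair of measured compounds shares this exact change, so there is nothing to read the size of the step from. Given that compound 1 is already at the limit and compound 2 is also weak, the step from compound 1 to compound 3 is expected to be small, a step that the limit leaves unreadable from compound 1 to compound 3, without a clear direction beyond the scatter. Compound 3 is therefore estimated at 110000 nM, with a likely range from 40000 nM to 300000 nM, and a fair chance that only a limit is reported again.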

Compound 3, half-maximal inhibitory concentration: > 100000 nM
Compound 3 ended at the assay's limit; the forecaster's own chance of this, stated with the estimate: 50%; the middle value lies beyond the limit too.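

Compound 1 and compound 3 both end at a limit of this assay and not at a number, so no step can be read between them: the limit of > 100000 nM in this assay, at which 2 of the 3 values shown sit.

The compounds shown leave open whether hydrogen in place of hydroxy on an aromatic carbon changes inhibition in this assay at all, and in which direction.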